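Swapping the aryl group on the triazole nitrogen of compound 1

The compounds below may be only part of what the source reports. "The series", "measured", "known", "first", "only" and "open" are said of these compounds alone.

Compound 1, `CC(C)(C)OC(=O)N1CCN(C(=S)SCc2cn(-c3ccccc3F)nn2)CC1`: 119000 nM
Compound 2, `CC(C)(C)OC(=O)N1CCN(C(=S)SCc2cn(Cc3cc(=O)oc4cc(O)ccc34)nn2)CC1`: 4960 nM
Compound 3, `O=C(OCc1ccccc1)N1CCN(C(=S)SCc2cn(Cc3ccccc3F)nn2)CC1`: 5060 nM

All three compounds were tested in a functional assay on MGC-803 cells (Homo sapiens) for inhibition, read by MTT assay, with a stated time of 72 h; a higher number here means a weaker inhibitor, a lower number a stronger inhibitor. Compound 1 stands at the highest number of the three, so it is the weakest inhibitor of this set; compound 3 and compound 2 both lie far below it, each by a gap beyond the scatter. Compound 2 and compound 3 sit close to one another, and no order can be read between them.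

The unmeasured compound 4, `COc1ccc(-n2cc(CSC(=S)N3CCN(C(=O)OC(C)(C)C)CC3)nn2)cc1`, differs from compound 1 in a single place: 4-methoxyphenyl in place of 2-fluorophenyl on an aromatic nitrogen. Among the measured compounds shown here, no measured pair isolates this kind of change, and compound 2 and compound 3 each differ from compound 1 in more than one place, so they give no direct guide. The step from compound 1 to compound 4 is expected to be small, likely a modest move toward a lower number, yet possibly within the scatter, a 2.4-fold lower number from compound 1 to compound 4 (0.38 log units; beyond the scatter). Compound 4 is therefore estimated at 50000 nM, in a range from 12000 nM to 150000 nM.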

Compound 4, half-maximal inhibitory concentration: 87300 nM
For compound 4 the middle estimate is 1.7-fold (0.24 log units) below the measured one; measured number inside the range.
By their numbers in this assay, from the lowest: compounds 2 and 3 (each within the scatter of the next); then compounds 4 and 1 (each within the scatter of the next).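

In this assay, among the compounds shown here, the swap of 2-fluorophenyl for 4-methoxyphenyl on the aromatic nitrogen gives a 1.4-fold lower number from compound 1 to compound 4 (0.13 log units; within the scatter), the first step here that isolates this position. The two compounds cannot be told apart, even though the group that enters brings one hydrogen-bond acceptor and carries its substituent at a different place on the phenyl ring. Nothing measured here explains why this swap leaves the reading within the scatter.

Still open, as far as these compounds go, is whether the kind of substituent or its place on the ring matters more, which 4-fluorophenyl or 2-methoxyphenyl could help to separate. Also open, from the compounds shown here alone, is whether a more different group on the phenyl ring, such as an amine or a carboxylic acid, would give a reading beyond the scatter.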